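The compounds below may be only part of what the source reports. "The series", "measured", "known", "first", "only" and "open" are said of these compounds alone.

Measured so far in a functional assay on the whole organism (strain Swiss) with Mus musculus as the target, in the maximal electroshock model, with a stated time of 0.25 h, at a dose of 300 mg/kg by the intraperitoneal route; on this read-out higher numbers stand for a stronger effect at the one dose given and lower numbers for a weaker effect:
compound 1 `COc1cccc(N2CCN(C(=O)C(C)N3C(=O)CCC3=O)CC2)c1`, 75%
compound 2 `CC(C(=O)N1CCN(c2ccccc2)CC1)N1C(=O)CCC1=O`, 100%
compound 3 `CCC(C(=O)N1CCN(c2cccc(OC)c2)CC1)N1C(=O)CCC1=O`, 25%

Compound 3 stands lowest of the three numbers in this assay; its nearest neighbour is compound 1, and the gap is a number 50 percentage points lower from compound 1 to compound 3 (beyond the scatter), the change there being methyl in place of hydrogen on a saturated chain carbon. Compound 2 lies furthest from it.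

Compound 4 `CCC(C(=O)N1CCN(c2ccccc2F)CC1)N1C(=O)CCC1=O` keeps that methyl and changes the aryl group instead: 2-fluorophenyl in place of 3-methoxyphenyl on an amine nitrogen in a ring. Among the compounds with values here, only one measured step touches the aryl group, a number 25 percentage points higher from compound 1 to compound 2 (beyond the scatter), where hydrogen replaces methoxy on an aromatic carbon. Here the methoxy also leaves, but a fluorine enters on the phenyl ring, and no measured pair shows what a fluorophenyl does in this assay. The step of a number 25 percentage points higher from compound 1 to compound 2 (beyond the scatter) is taken as a loose hint that losing the methoxy tends to raise the number, so a rise of a number 25 percentage points higher from compound 3 to compound 4 (beyond the scatter) is expected, with wide uncertainty.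

Compound 4 is estimated at 50%, range 0% to 100%.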

Compound 4, a percentage reported as activity, at one dose (the size of the read-out at that dose, not a potency): 100%
For compound 4 the middle estimate is 50 percentage points below the measured one; low and high end bracket the measured number.
By their numbers in this assay, from the lowest: compound 3; then compound 1; then compounds 2 and 4 (each within the scatter of the next).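

In this assay the aryl group on the amine nitrogen in a ring moves the number strongly even with the chain methyl kept: 2-fluorophenyl in place of 3-methoxyphenyl gives a number 75 percentage points higher from compound 3 to compound 4 (beyond the scatter). The low number of compound 3 therefore does not follow from the chain methyl alone; it depends on which aryl group accompanies that methyl. No measurement at hand explains this change.

The compounds shown leave open how much of the step belongs to the loss of the methoxy, how much to the entry of the fluorine, and whether the place of the fluorine on the phenyl ring matters. Also open, going by these compounds, is how a chlorophenyl or a trifluoromethylphenyl would read on the same ring nitrogen with the chain methyl kept.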